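The source may report more compounds than this note shows. Statements on the series, on what has been measured and on what is new or still open speak of the compounds shown alone.

Compound 1 `CC(=O)c1ccc(N2CCN(C(=O)c3oc(C)nc3-c3ccccc3)CC2)cc1` is a piperazine amide carrying a 4-acetylphenyl group on one ring nitrogen. In a functional assay on HL-60 cells (Homo sapiens) for inhibition, read by MTT assay, with a stated time of 72 h (on this read-out lower numbers stand for stronger inhibition and higher numbers for weaker inhibition), compound 1 gives "not active" (no number reported), so no single number stands for it, and it can only be placed among the weakest compounds here. Compound 2 `CCc1nc(-c2ccccc2Cl)c(C(=O)N2CCN(c3cccc(Cl)c3)CC2)o1`, a relative with a different oxazole substituent, a chlorine on its phenyl and a 3-chlorophenyl on the ring nitrogen, gives 98.9 nM in this assay, which shows that this family can reach sub-micromolar inhibition.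

Compound 3 `Cc1nc(-c2ccccc2)c(C(=O)N2CCN(c3ccc(Cl)c(Cl)c3)CC2)o1` keeps the core of compound 1 and changes one place: 3,4-dichlorophenyl in place of 4-acetylphenyl on an amine nitrogen in a ring. Going by the values given here, because compound 1 gives "not active" (no number reported), no measured step can be computed for this change. The step is expected to move toward stronger inhibition, that is toward lower numbers in this assay, and to be larger than the usual scatter, because compound 2, which also bears a chlorine-substituted phenyl on the ring nitrogen, gives 98.9 nM. Compound 3 is therefore estimated at 600 nM, with a range from 120 nM to 6000 nM.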

Compound 3, half-maximal inhibitory concentration: 124 nM
Beside the measured number, compound 3's estimate is 4.8-fold (0.68 log units) above it; the range from low to high includes it.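

With no number for compound 1 in this assay no size can be given for the change from compound 1 to compound 3, so no step can be read. Nothing measured here gives a cause for the result of compound 3. The compounds shown leave open how much the 3,4-dichlorophenyl group alone contributes to that result.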